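Swapping methoxy for ethyl on the chain of compound 2

The compounds below may be only part of what the source reports. "The series", "measured", "known", "first", "only" and "open" are said of these compounds alone.

Of the compounds shown here, three sharing one core have been measured in an assay on isolated protein for inhibition of Amine oxidase [flavin-containing] A (Homo sapiens), read by fluorescence and Amplex Red, with a stated time of 30 min, tested at 1 uM; on this read-out lower numbers stand for a weaker effect and higher numbers for a stronger effect at the one concentration tested. Compound 1 `C=CCNc1nnc(SCC(=O)N(Cc2cccc([N+](=O)[O-])c2)c2ccc(F)cc2)s1` gives 56.5%. Compound 2 `COCCNc1nnc(SCC(=O)N(Cc2cccc([N+](=O)[O-])c2)c2ccc(F)cc2)s1` gives 72.7%, the highest of the three numbers. Compound 3 `CCNc1nnc(SCC(=O)N(Cc2cccc([N+](=O)[O-])c2)c2ccc(F)cc2)s1` gives 61.9%. The step of a number 16.2 percentage points higher from compound 1 to compound 2 (beyond the scatter) is modest but beyond the scatter, and the step of a number 10.8 percentage points lower from compound 2 to compound 3 (beyond the scatter) is also modest and beyond the scatter, while the step of a number 5.4 percentage points higher from compound 1 to compound 3 (within the scatter) stays within it.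

Compound 4 `CCCCNc1nnc(SCC(=O)N(Cc2cccc([N+](=O)[O-])c2)c2ccc(F)cc2)s1` has not yet been measured. It differs from compound 2 in one place: ethyl in place of methoxy on a saturated chain carbon, two bonds along the chain from a nitrogen on an aromatic ring. The step that bears most directly on this change is a number 10.8 percentage points lower from compound 2 to compound 3 (beyond the scatter), where the methoxy was simply removed. Here the methoxy is replaced by ethyl, so a modest drop in this assay of similar size is expected, not a gain. The estimated step is a number 12.7 percentage points lower from compound 2 to compound 4 (beyond the scatter). For compound 4 the expected value in this assay is 60%, with a likely range from 45% to 75%.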

Compound 4, a percentage reported as inhibition, at one concentration (the size of the read-out at that concentration, not a potency): 47.3%
Estimate against measurement, compound 4: 12.7 percentage points above; the measured number falls inside the stated range.
By their numbers in this assay, from the lowest: compounds 4, 1 and 3 (each within the scatter of the next, the first and the last beyond it); then compound 2.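

Butyl and 2-methoxyethyl have the same number of heavy atoms, yet the step is a number 25.4 percentage points lower from compound 2 to compound 4 (beyond the scatter) in this assay, so in this pair the count of heavy atoms alone does not set the number; the change removes the oxygen and its one hydrogen-bond acceptor. A longer all-carbon chain brings no gain in this series either, with ethyl in place of hydrogen giving a number 14.6 percentage points lower from compound 3 to compound 4 (beyond the scatter). The remaining step, a number 9.2 percentage points lower from compound 1 to compound 4 (within the scatter), does not separate the butyl chain of compound 4 from the chain of compound 1.

Nothing here explains why the two chains of equal heavy-atom count differ. Going by these compounds, whether a hydroxy group or an amine in place of the methoxy would keep the number of compound 2 remains open.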